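This account rests on a few compounds, and the source may have more. Where it says the series, first, only, none or still open, it means among the compounds named here.

The measured compounds and their values in a functional assay on A-375 cells (Homo sapiens) for cytotoxicity, read by MTT assay, with a stated time of 72 h, tested at 100 uM; on this read-out lower numbers stand for less inhibition of growth and higher numbers for more inhibition of growth at the one concentration tested:
compound 1 `N/C(=N\NC(=S)N1CCOCC1)c1ccccn1` gives 14%;
compound 2 `Cc1ccnc(/C(N)=N/NC(=S)N2CCSCC2)c1` gives 89.9%;
compound 3 `N/C(=N\NC(=S)N1CCSCC1)c1ccccn1` gives 87.8%.

Compound 3 stands second highest of the three numbers: the step of a number 2.1 percentage points lower from compound 2 to compound 3 (within the scatter) is within the scatter, whereas the step of a number 73.8 percentage points higher from compound 1 to compound 3 (beyond the scatter) is large. Compound 4 `N/C(=N\NC(=S)N1CCCCC1)c1ccccn1` differs from compound 3 by piperidin-1-yl in place of thiomorpholin-4-yl on a thiocarbonyl carbon. Going by the values given here, no measured step covers this exact exchange; the only step at the same place, a number 73.8 percentage points higher from compound 1 to compound 3 (beyond the scatter), shows that the ring on the thiocarbonyl carbon can matter greatly. The entering ring, like thiomorpholine, lacks the oxygen present in compound 1, so a moderate downward step in this assay is expected, with wide uncertainty. Compound 4 is therefore estimated at 60%, between 20% and 95%, which amounts to an expected a number 27.8 percentage points lower from compound 3 to compound 4 (beyond the scatter).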

Compound 4, percent growth inhibition at one concentration: 88.5%
Compound 4: the middle estimate sits 28.5 percentage points below what was measured; low and high end bracket the measured number.
By their numbers in this assay, from the lowest: compound 1; then compounds 3, 4 and 2 (each within the scatter of the next).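

On the thiocarbonyl carbon, exchanging thiomorpholin-4-yl for piperidin-1-yl gives a number 0.7 percentage points higher from compound 3 to compound 4 (within the scatter) in this assay, so a ring without a second hetero atom does as well here as the sulfur ring. Going by these compounds alone, exchanging morpholin-4-yl for piperidin-1-yl gives a number 74.5 percentage points higher from compound 1 to compound 4 (beyond the scatter), which leaves morpholin-4-yl as the only one of these three rings with a low number. No evidence is available on what lies behind this difference. As far as these compounds go, it remains open whether a pyrrolidin-1-yl ring, a piperazin-1-yl ring or an open-chain dimethylamino group at this place would keep the high numbers.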